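A few compounds are considered here, and "the series" means these few. Any claim that something is new, unique, unknown or untested is made for them only; others in the source may bear on it.

Measured so far in a functional assay on HEK293 cells for agonist activity at G-protein coupled receptor 84 (Homo sapiens), read by calcium flux; on this read-out lower numbers stand for an effect already at smaller amounts and higher numbers for an effect only at larger amounts of compound: compound 1, `CC(C)CCCc1nc(O)cc(O)n1`, gives 2110 nM; compound 2, `CCCCCc1nc(O)cc(O)n1`, gives 3670 nM; compound 3, `CCCCCCCC(C)c1nc(O)cc(O)n1`, gives 299 nM.

Compound 1 and compound 2 differ in one place: hydrogen in place of methyl on a saturated chain carbon bound to two saturated chain carbons. The resulting step, a 1.7-fold higher number from compound 1 to compound 2 (0.24 log units; within the scatter), lies within the scatter. Compound 3 has the lowest of the three numbers, and its steps to compound 1 and compound 2 are both beyond the scatter; how its core differs from that of compound 1 is not broken down here.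

Compound 4, `CCCCCCCCc1nc(O)cc(O)n1`, has not yet been measured in this assay. It differs from compound 3 by hydrogen in place of methyl on a saturated chain carbon bound to an aromatic carbon and a saturated chain carbon. This is the same kind of change as that from compound 1 to compound 2, but the place is not the same: there the carbon was bound to two saturated chain carbons, here it is bound to an aromatic carbon and a saturated chain carbon. Since the earlier step of a 1.7-fold higher number from compound 1 to compound 2 (0.24 log units; within the scatter) stayed within the scatter, a similarly small step is expected here, starting from compound 3 at 299 nM. For compound 4 the expected value in this assay is 500 nM, between 200 nM and 1500 nM. The step this estimate implies, a 1.7-fold higher number from compound 3 to compound 4 (0.22 log units; within the scatter), is expected to stay modest.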

Compound 4, half-maximal effective concentration: 11.4 nM
Beside the measured number, compound 4's estimate is 44-fold (1.64 log units) above it, and the stated range ends above it.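

In this assay, hydrogen in place of methyl on a saturated chain carbon bound to an aromatic carbon and a saturated chain carbon gives a 26-fold lower number from compound 3 to compound 4 (1.42 log units; beyond the scatter), propyl in place of hydrogen gives a 320-fold lower number from compound 2 to compound 4 (2.51 log units; beyond the scatter), and pentyl in place of isopropyl gives a 190-fold lower number from compound 1 to compound 4 (2.27 log units; beyond the scatter). The step from methyl to hydrogen therefore did not carry over unchanged from one core to the other: the same change on two cores in this assay, a 1.7-fold higher number (0.24 log units; within the scatter) from compound 1 to compound 2 and a 26-fold lower number (1.42 log units; beyond the scatter) from compound 3 to compound 4, 46-fold (1.66 log units) apart, beyond the scatter of two such steps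
This shows that, in this series, a small step on one core said little about the size of the same kind of change on another, but it does not show why, as the methyl sits at a different place in each pair and these two pairs cannot separate place from core.

The compounds shown leave open whether a longer chain than that of compound 4 would give a still lower number. They also leave open how a carboxylic acid or an amine at the end of the chain would fare.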